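Removing the Chloro Group from the Benzyl Amine

This account rests on a few compounds, and the source may have more. Where it says the series, first, only, none or still open, it means among the compounds named here.

Compound 3 `CN(CCCCn1c(=O)oc2ccccc21)Cc1cccc(Cl)c1` shows the highest number of the three measured compounds: in an assay on membranes from liver for displacement of a labelled ligand from Sigma non-opioid intracellular receptor 1 (Rattus norvegicus), read by scintillation counting (a higher number here means a weaker inhibitor, a lower number a stronger inhibitor), compound 3 gives 302 nM. Compound 1 `Cc1cccc(CN(C)CCCCn2c(=O)oc3ccccc32)c1` gives 102 nM, and compound 2 `Cc1ccc(CN(C)CCCCn2c(=O)oc3ccccc32)cc1` gives 97 nM. The change to compound 4 `CN(CCCCn1c(=O)oc2ccccc21)Cc1ccccc1` is hydrogen in place of chloro on an aromatic carbon. Among the compounds with values here, two measured steps bear on this: a 3.0-fold higher number from compound 1 to compound 3 (0.47 log units; beyond the scatter) and a 3.1-fold higher number from compound 2 to compound 3 (0.49 log units; beyond the scatter). Both show a modest rise in the number when chloro replaces methyl on the aromatic carbon; hydrogen at that position has not been measured, so its result may not match methyl. Compound 4 is therefore expected to give a somewhat lower number than compound 3, a 1.6-fold lower number from compound 3 to compound 4 (0.20 log units; within the scatter). The estimate for compound 4 is 190 nM, within a range of 80 nM to 450 nM.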

Compound 4, inhibition constant: 2.6 nM
Compound 4: the middle estimate sits 73-fold (1.86 log units) above what was measured, and the stated range ends above it.
By their numbers in this assay, from the lowest: compound 4; then compounds 2 and 1 (each within the scatter of the next); then compound 3.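

In this assay, the bare phenyl ring stands well apart from its substituted relatives, with a 120-fold lower number from compound 3 to compound 4 (2.07 log units; beyond the scatter) on losing chloro. Losing methyl also counts heavily, with a 39-fold lower number from compound 1 to compound 4 (1.59 log units; beyond the scatter) and a 37-fold lower number from compound 2 to compound 4 (1.57 log units; beyond the scatter), so the gap between chloro and methyl is small beside the gap between either group and hydrogen. No measurement here explains this drop in the number. As far as these compounds go, whether fluoro or methoxy on this ring would also raise the number remains open. So does whether any group at all can be placed there without a similar rise.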